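Same ring exchange on a sulfoxide, then on a sulfone

A few compounds are considered here, and "the series" means these few. Any claim that something is new, unique, unknown or untested is made for them only; others in the source may bear on it.

Compound 1 `Nc1nnc(-c2ccccc2[S+]([O-])c2ccccc2)o1` gives 29.4% in a functional assay on the whole organism (strain NMRI) for inhibition, with Mus musculus as the target, in the formalin test, with a stated time of 30 min, at a dose of 30 umol/kg by the intraperitoneal route; a higher number here means more inhibition at the dose given (going by the name of the read-out), a lower number less inhibition. Compound 2 `Nc1nnc(-c2ccccc2S(=O)(=O)c2ccccc2)o1` gives 40.5% in this assay. Compound 3 `[O-][S+](c1ccccc1)c1ccccc1-c1n[nH]c(=S)[nH]1` gives 31.7% in this assay.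

Compound 3 arises from compound 1 by a group of 6 heavy atoms (2 carbon, 3 nitrogen, 1 sulfur; one five-membered aromatic ring with 3 hetero atoms) in place of a group of 6 heavy atoms (2 carbon, 3 nitrogen, 1 oxygen; one five-membered aromatic ring with 3 hetero atoms), on an aromatic carbon, and that step is a number 2.3 percentage points higher from compound 1 to compound 3 (within the scatter). Compound 4 `O=S(=O)(c1ccccc1)c1ccccc1-c1n[nH]c(=S)[nH]1`, not yet measured, arises from compound 2 by a group of 6 heavy atoms (2 carbon, 3 nitrogen, 1 sulfur; one five-membered aromatic ring with 3 hetero atoms) in place of a group of 6 heavy atoms (2 carbon, 3 nitrogen, 1 oxygen; one five-membered aromatic ring with 3 hetero atoms), on an aromatic carbon. The difference between the cores of compound 1 and compound 2 is not broken down here; the place of the exchange, as given with each of the two differences, is not identical in the two pairs, so the two changes are of the same kind, not the same. Compound 2 lies within the scatter of compound 3 and beyond it from compound 1. For compound 4 a step of a number 2.5 percentage points higher from compound 2 to compound 4 (within the scatter) is expected, resting on the step of a number 2.3 percentage points higher from compound 1 to compound 3 (within the scatter) seen for compound 1 and compound 3. Compound 4 is thus estimated at 43%, between 30% and 56%.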

Compound 4, a percentage reported as inhibition, in the whole organism at one dose (the size of the read-out at that dose, not a potency): 31.2%
Compound 4: the middle estimate sits 11.8 percentage points above what was measured, and the stated range covers the measured number.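

In this assay the same ring exchange on the sulfone comes out as a number 9.3 percentage points lower from compound 2 to compound 4 (within the scatter). Set beside the exchange on the sulfoxide, the two steps cannot be told apart: the same change on two cores in this assay, a number 2.3 percentage points higher (within the scatter) from compound 1 to compound 3 and a number 9.3 percentage points lower (within the scatter) from compound 2 to compound 4, 11.6 percentage points apart, within the scatter of two such steps This shows no detectable dependence of the exchange on the core across these two pairs, but it does not show that the two cores respond alike, since each step lies within the scatter and a real difference of that size would pass unseen.

The compounds shown leave open what a carboxylic acid or an open-chain amide would give in place of the five-membered ring. They also leave open how a simple thioether would compare with the sulfoxide and the sulfone.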